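The source may report more compounds than this note shows. Statements on the series, on what has been measured and on what is new or still open speak of the compounds shown alone.

Working notes on the series. Among the measured compounds shown here, compound 2 `CCN(CC)CN1C(=O)/C(=N\c2nc3ccc(C)cc3s2)c2ccccc21` holds the lowest of the two numbers so far: in an ADME assay on 184B5 cells (Homo sapiens) for cytotoxicity, read by sulforhodamine B assay, with a stated time of 48 h (on this read-out lower numbers stand for stronger inhibition of growth and higher numbers for weaker inhibition of growth), compound 2 gives 27500 nM. Its nearest neighbour on this read-out is compound 1 `Cc1ccc2nc(/N=C3\C(=O)N(CN4CCCCC4)c4cccc(Br)c43)sc2c1`, which in this assay gives 85200 nM, a higher number by a gap beyond the scatter. Compound 3 `Cc1ccc2nc(/N=C3\C(=O)N(CN4CCCCC4)c4ccccc43)sc2c1` has not yet been measured in this assay. The change from compound 2 to compound 3 is piperidin-1-yl in place of diethylamino on a saturated chain carbon bound to an amide-type nitrogen in a ring. For the measured compounds named here, compound 1 differs from compound 3 in more than one place, so its number offers no clean single step for this change, and no measured pair isolates it. The step expected from this change in this assay is a 1.5-fold higher number from compound 2 to compound 3 (0.16 log units; within the scatter), modest and toward a higher number, with little confidence in the direction. Compound 3 is therefore estimated at 40000 nM, within a range of 15000 nM to 100000 nM.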

Compound 3, concentration for 50% growth inhibition: 34900 nM
Compound 3: the middle estimate sits 1.1-fold (0.06 log units) above what was measured, and the stated range covers the measured number.
By their numbers in this assay, from the lowest: compounds 2 and 3 (each within the scatter of the next); then compound 1.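

In this assay, piperidin-1-yl in place of diethylamino on a saturated chain carbon bound to an amide-type nitrogen in a ring gives a 1.3-fold higher number from compound 2 to compound 3 (0.10 log units; within the scatter), so this read-out does not separate the open-chain amine from the six-membered ring at this place. Hydrogen in place of bromo on an aromatic carbon gives a 2.4-fold lower number from compound 1 to compound 3 (0.39 log units; beyond the scatter), the only one of the two single changes shown that lies beyond the scatter. No measured evidence bears on the size of either step.

Open, as far as these compounds go, is whether morpholin-4-yl on the same saturated chain carbon would stay within the scatter of compound 3, and whether chloro or methoxy in place of bromo would give a step of like size. Also open, from the compounds shown here alone, is whether the bromo step would hold with diethylamino in place of piperidin-1-yl.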